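This account rests on a few compounds, and the source may have more. Where it says the series, first, only, none or still open, it means among the compounds named here.

Measured compounds:
- Compound 1, `COc1cc2nnc(C(N)=O)c(Nc3ccc(F)cc3F)c2cc1OC`: 3000 nM
- Compound 2, `COc1cc2nnc(C(N)=O)c(Nc3cc(C)ccc3F)c2cc1OC`: < 1000 nM
- Compound 3, `CCOc1cc2nnc(C(N)=O)c(Nc3ccc(C)cc3F)c2cc1N1CCN(C)CC1`: 27000 nM

All three share one core and differ in the aryl group on the aniline nitrogen and in the substituents on the other side of the core. In a physicochemical assay for solubility (on this read-out lower numbers stand for lower solubility and higher numbers for higher solubility), compound 1 gives 3000 nM. Compound 2 reaches only a limit of this assay, < 1000 nM, which is a boundary and not a number. Compound 3 gives 27000 nM, the highest value among the measured compounds.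

The step to compound 4, `CCOc1cc2nnc(C(N)=O)c(Nc3cccc(Cl)c3F)c2cc1N1CCN(C)CC1`, changes only the aryl group on the nitrogen: 3-chloro-2-fluorophenyl in place of 2-fluoro-4-methylphenyl on a nitrogen on an aromatic ring. Among the compounds with values here, the one measured step of the same kind is the aryl swap an at least 3.0-fold lower number from compound 1 to compound 2 (0.47 log units; beyond the scatter), which lowered solubility beyond the scatter and ended at a limit (the limit of < 1000 nM in this assay, at which 1 of the 3 values shown sits). Within the data shown here, that step exchanged a fluorine for a methyl; the present step exchanges a methyl for a chlorine and relocates the fluorine, so it is only a loose guide, and no measured step covers a chlorine here.

A small drop, or no change beyond the scatter, is therefore expected, a 1.8-fold lower number from compound 3 to compound 4 (0.26 log units; within the scatter). Compound 4 is estimated at 15000 nM, within 4000 nM to 50000 nM.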

Compound 4, solubility: 18000 nM
Beside the measured number, compound 4's estimate is 1.2-fold (0.08 log units) below it; low and high end bracket the measured number.
By their numbers in this assay, from the lowest: compound 1; then compounds 4 and 3 (each within the scatter of the next). At a limit, below all of these: compound 2.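

In this assay, 3-chloro-2-fluorophenyl in place of 2-fluoro-4-methylphenyl on a nitrogen on an aromatic ring gives a 1.5-fold lower number from compound 3 to compound 4 (0.18 log units; within the scatter), so this exchange of groups, which brings in a chlorine and removes a methyl, leaves the read-out within the scatter. It is the first aryl change shown with a true number at both ends, and it differs from the earlier aryl change that led to compound 2, which went beyond the scatter, so at this position an aryl change does not always shift the read-out measurably. Compound 2 is the only compound shown that stands at a limit, and it plays no part in this new step: the limit of < 1000 nM in this assay, at which 1 of the 4 values shown sits.

On these data alone, whether this same aryl exchange would behave alike with the other substituents of compound 1 remains open. Also open is how this assay would respond to an aryl group on this nitrogen that carries an amine or a carboxylic acid, since every aryl group shown holds only halogens or a methyl.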